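This account rests on a few compounds, and the source may have more. Where it says the series, first, only, none or still open, it means among the compounds named here.

Of the compounds shown here, three built on a shared core have been measured in an assay on CHO cells for displacement of a labelled ligand from adenosine receptor A1 (Homo sapiens), read by scintillation counting, with a stated time of 90 min; a lower number here means a stronger inhibitor, a higher number a weaker inhibitor. Compound 1 `CCOc1ccc(-c2c(C#N)c(N)nc(SCc3ccn[nH]3)c2C#N)cc1` gives 21 nM, compound 2 `C=CCOc1ccc(-c2c(C#N)c(N)nc(SCC(N)=O)c2C#N)cc1` gives 323 nM, and compound 3 `N#Cc1c(N)nc(SCc2cccc(C(N)=O)c2)c(C#N)c1-c1ccc(OCC2CC2)cc1` gives 83 nM. Compound 3 thus holds the second highest of the three numbers, with compound 1 the stronger inhibitor and compound 2 the weaker one. Compound 4 `N#Cc1c(N)nc(SCC(=O)NO)c(C#N)c1-c1ccc(OCC2CC2)cc1` differs from compound 3 in one place: hydroxycarbamoyl in place of 3-carbamoylphenyl on a saturated chain carbon bound to a sulfur. Among the compounds with values here, no measured pair shows exactly this change, but compound 2, which also carries a carbamoyl group on a saturated chain carbon bound to a sulfur, gives 323 nM. Compound 4 is therefore expected to be a weaker inhibitor, with the step from compound 3 to compound 4 estimated at a 3.6-fold higher number from compound 3 to compound 4 (0.56 log units; beyond the scatter). The estimate for compound 4 is 300 nM, within a likely range from 100 nM to 1000 nM.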

Compound 4, inhibition constant: 536 nM
Compound 4: the middle estimate sits 1.8-fold (0.25 log units) below what was measured, and the stated range covers the measured number.
By their numbers in this assay, from the lowest: compound 1; then compound 3; then compounds 2 and 4 (each within the scatter of the next).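

In this assay, putting hydroxycarbamoyl in place of 3-carbamoylphenyl on a saturated chain carbon bound to a sulfur gives a 6.5-fold higher number from compound 3 to compound 4 (0.81 log units; beyond the scatter). Within the data shown here, this is the first direct comparison at this position, and it shows that the group placed there changes the number, with the rest of compound 3 held constant. No available evidence explains this step.

As far as these compounds go, the change removes the ring and alters the end group together, so the separate contribution of each stays unknown. From the compounds shown here alone, whether a plain phenyl or a carboxylic acid in that place would behave more like compound 3 or compound 4 also remains open.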